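Cyclopropyl in Place of Pentyl: an Estimate for Compound 4

The compounds below may be only part of what the source reports. "The series", "measured", "known", "first", "only" and "open" are said of these compounds alone.

Measured compounds and their values:
Compound 1, `CCCCCc1cc2nn(-c3ccccc3)cc2cn1`: 2100 nM
Compound 2, `Cn1cc2cnc(-c3ccccc3)cc2n1`: > 100000 nM, a limit of the assay
Compound 3, `CCCCCc1cc2nn(-c3ccccc3)cc2c(C)n1`: 6900 nM

Three compounds on a shared core have been examined in a functional assay on K562 cells (Homo sapiens) for inhibition, read by fluorescence, with a stated time of 72 h; on this read-out lower numbers stand for stronger inhibition of growth and higher numbers for weaker inhibition of growth. Compound 1 gives the lowest of the two numbers reported. Among the compounds with values here, the one single-point step measured so far is a 3.3-fold higher number from compound 1 to compound 3 (0.52 log units; beyond the scatter), which adds methyl on an aromatic carbon and leaves the pentyl group untouched. Compound 2 returns only a limit, (the limit of > 100000 nM in this assay, at which 1 of the 3 values shown sits), so it contributes no number to weigh.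

Compound 4, `c1ccc(-n2cc3cnc(C4CC4)cc3n2)cc1`, is not yet measured. Its difference from compound 1 is cyclopropyl in place of pentyl on an aromatic carbon. Within the data shown here, no measured step in this assay alters that group, and the step from compound 1 to compound 3 concerns a different position, so it offers no direct guide to the size of the change. With only this thin basis, a modest weakening relative to compound 1 is expected in this assay rather than a gain, but the range must stay wide. Compound 4 is estimated at 6000 nM, with a range from 1500 nM to 25000 nM. That estimate corresponds to an expected step of a 2.9-fold higher number from compound 1 to compound 4 (0.46 log units; beyond the scatter).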

Compound 4, concentration for 50% growth inhibition: 60500 nM
For compound 4 the middle estimate is 10-fold (1.00 log units) below the measured one, outside the stated range (above it).
By their numbers in this assay, from the lowest: compound 1; then compound 3; then compound 4. At a limit, above all of these: compound 2.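

In this assay the aromatic carbon next to the ring nitrogen proves a sensitive place: cyclopropyl in place of pentyl brings a 29-fold higher number from compound 1 to compound 4 (1.46 log units; beyond the scatter) and counts as a large step, while methyl in place of hydrogen at a different position brought a 3.3-fold higher number from compound 1 to compound 3 (0.52 log units; beyond the scatter) and counts as a modest one. Most of the growth inhibition seen with compound 1 is therefore lost when its open pentyl chain gives way to the smaller three-membered ring, so the group at this place weighs heavily on the shared core. This single change removes chain atoms and adds a ring together, and nothing shown explains the loss or separates those two parts.

The compounds shown leave open whether a butyl or hexyl chain would keep the number of compound 1 at this place, and whether a cyclopentyl ring would recover what cyclopropyl gives up. They also leave open how an amine or a carboxylic acid at the end of the pentyl chain would read in this assay on this core.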